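The source may report more compounds than this note shows. Statements on the series, on what has been measured and on what is new or still open speak of the compounds shown alone.

Compound 1 `Cc1cc(F)ccc1Nc1ncnc2cc(NC(=O)CCCCCCC(=O)NO)sc12` gives 120 nM in an assay on cells for inhibition of protein deacetylase HDAC6 (Homo sapiens), with a stated time of 3 h; a lower number here means a stronger inhibitor, a higher number a weaker inhibitor. Compound 2 `COc1ccc(Nc2ncnc3cc(NC(=O)CCCCCCC(=O)NO)sc23)c(C)c1` gives 111 nM. Compound 3 `CCc1cccc(Nc2ncnc3cc(NC(=O)CCCCCCC(=O)NO)sc23)c1` gives 58.5 nM.

Compound 3 has the lowest number of the three: the step of a 2.1-fold lower number from compound 1 to compound 3 (0.31 log units; beyond the scatter) lies beyond the scatter, whereas a 1.9-fold lower number from compound 2 to compound 3 (0.28 log units; within the scatter) and a 1.1-fold lower number from compound 1 to compound 2 (0.03 log units; within the scatter) do not. Compound 4 `N#Cc1cccc(Nc2ncnc3cc(NC(=O)CCCCCCC(=O)NO)sc23)c1` differs from compound 3 by cyano in place of ethyl on an aromatic carbon. Going by the values given here, no measured step exchanges an ethyl for a cyano; the only steps that bear on the change are those altering the substituents on the anilino ring, and both were modest. The expected movement in this assay is therefore small, probably none beyond the scatter, and is estimated as a 1.4-fold higher number from compound 3 to compound 4 (0.14 log units; within the scatter). Compound 4 is expected to give 80 nM, with a range from 35 nM to 200 nM.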

Compound 4, half-maximal inhibitory concentration: 20.1 nM
The estimate for compound 4 lay 4.0-fold (0.60 log units) above the measured number, outside the stated range (below it).
By their numbers in this assay, from the lowest: compound 4; then compounds 3, 2 and 1 (each within the scatter of the next, the first and the last beyond it).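

In this assay, exchanging ethyl for cyano on this aromatic carbon, with the heavy-atom count unchanged and one hydrogen-bond acceptor added, gives a 2.9-fold lower number from compound 3 to compound 4 (0.46 log units; beyond the scatter). Going by these compounds alone, this shows that a single group at this place can move the number beyond the scatter, which no earlier step confined to one group had done. The 3-cyanophenyl group also stands clear of both other anilino groups, with a 5.5-fold lower number from compound 2 to compound 4 (0.74 log units; beyond the scatter) and a 6.0-fold lower number from compound 1 to compound 4 (0.78 log units; beyond the scatter).

Nothing available explains these steps. Going by these compounds, whether an amine or a carboxylic acid at this place would give a lower or higher number remains open.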